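Thiourea tail trimmed: from compound 3 to compound 4

The compounds below may be only part of what the source reports. "The series", "measured", "known", "first", "only" and "open" are said of these compounds alone.

Measured compounds:
Compound 1 `C/N=C(/NC#N)NCCCn1nc(-c2ccccc2)ccc1=O`: 40.5%
Compound 2 `CC/N=C(\S)NCCCCCCn1nc(-c2ccccc2)ccc1=O`: -5.6%
Compound 3 `O=c1ccc(-c2ccccc2)nn1CCCC/N=C(\S)Nc1ccc(S(=O)(=O)O)cc1`: 25.1%

In a functional assay on the whole organism with Rattus norvegicus as the target, at a dose of 100 mg/kg (on this read-out higher numbers stand for more inhibition at the one dose given (going by the name of the read-out) and lower numbers for less inhibition), compound 3 gives 25.1%, the second highest of the three numbers. Compound 1 gives 40.5%, which lies above compound 3 by more than the scatter, while compound 2 gives -5.6%, well below compound 3 and also beyond the scatter. No two of the measured compounds differ in a single place, so no isolated step can be read from them.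

Compound 4 `N/C(S)=N/CCCCn1nc(-c2ccccc2)ccc1=O` is the unmeasured compound. It differs from compound 3 as follows: hydrogen in place of 4-sulfophenyl on an amine nitrogen. The shared core and the thiourea remain; only the substituent on one amine nitrogen is removed.

No comparable change has been measured, so the expected step is uncertain. The author expects, given that compound 3 gives 25.1%, a step of a number 7.1 percentage points lower from compound 3 to compound 4 (within the scatter), that is a modest move downward that stays within the usual scatter. For compound 4 the estimate is 18%, with a range from -8% to 44%.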

Compound 4, a percentage reported as inhibition, in the whole organism at one dose (the size of the read-out at that dose, not a potency): 72%
Compound 4: the middle estimate sits 54 percentage points below what was measured; measured number above the stated range.
By their numbers in this assay, from the lowest: compound 2; then compound 3; then compound 1; then compound 4.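

In this assay, going by these compounds alone, putting hydrogen in place of 4-sulfophenyl on the amine nitrogen gives a number 46.9 percentage points higher from compound 3 to compound 4 (beyond the scatter), the first step here that can be read at a single place, and it shows that this substituent strongly affects the read-out. Compound 4 also stands above the two other compounds, with a number 77.6 percentage points higher from compound 2 to compound 4 (beyond the scatter) and a number 31.5 percentage points higher from compound 1 to compound 4 (beyond the scatter), although each of these swaps replaces a whole group on the saturated chain, so the chain and its end cannot be told apart. Nothing available here explains why the number rises.

The compounds shown leave open whether a methyl or a plain phenyl on that nitrogen would stay near compound 4 or near compound 3. They also leave open how the effect changes with dose, since only one dose is given.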